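Nitro in place of dimethylamino: working notes

A few compounds are considered here, and "the series" means these few. Any claim that something is new, unique, unknown or untested is made for them only; others in the source may bear on it.

- compound 1 (`CC1=CC[C@@H]([C@@](C)(O)CCCC(C)(C)NC(=S)N/N=C\c2ccc(C)cc2)CC1`), measured at (11800 nM)
- compound 2 (`CC1=CC[C@@H]([C@@](C)(O)CCCC(C)(C)NC(=S)N/N=C\c2ccc(N(C)C)cc2)CC1`), a limit only (> 100000 nM)
- compound 3 (`CC1=CC[C@@H]([C@@](C)(O)CCCC(C)(C)NC(=S)N/N=C\c2ccc([N+](=O)[O-])cc2)CC1`), not yet measured

All values come from (a functional assay on OVCAR-3 cells (Homo sapiens) for cytotoxicity, read by sulforhodamine B assay; a lower number here means a stronger inhibitor of growth, a higher number a weaker inhibitor of growth). Compound 2 has no number, and its entry (> 100000 nM) is a limit of the assay.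

The next change is nitro in place of dimethylamino on an aromatic carbon, para to a large group. For the measured compounds named here, one measured step bears on it, and it brought dimethylamino in place of methyl at that same site (an at least 8.4-fold higher number from compound 1 to compound 2 (0.92 log units; beyond the scatter)). Compound 3 gives that dimethylamino up again, so a move to a lower number is expected, back towards compound 1 (11800 nM). Going by the values given here, no measured compound carries nitro, so the size of the move remains uncertain, and a return all the way is not assumed.

The expected move is (an at least 5.0-fold lower number from compound 2 to compound 3 (0.69 log units; beyond the scatter)), an estimate resting on that single step. For compound 3 the estimated value is (20000 nM), with an expected range from (6000 nM) to (70000 nM).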

Compound 3, concentration for total growth inhibition: 88600 nM
The estimate for compound 3 lay 4.4-fold (0.65 log units) below the measured number; the whole stated range lies below it.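

Nitro at this site, para to a large group, does not bring the series back to the level of the methyl compound: in this assay the change reads as a 7.5-fold higher number from compound 1 to compound 3 (0.88 log units; beyond the scatter), so the higher number seen with dimethylamino is no longer confined to that one group, and compound 1 keeps the lowest number of the three. The entry for compound 2 is a limit of the assay, not a number: the limit of > 100000 nM in this assay, at which 1 of the 3 values shown sits. Measured against that limit, the remaining step is an at least 1.1-fold lower number from compound 2 to compound 3 (0.05 log units; that floor lies within the scatter), and as its floor lies within the scatter, nitro and dimethylamino cannot be placed in order at this site.

From the compounds shown here alone, whether compound 3 truly differs from compound 2 stays open, since the true value of compound 2 is unknown. Going by these compounds, it is also open whether methyl is particularly favoured here or whether other groups at the same site, such as a plain hydrogen, chlorine, methoxy or a longer alkyl chain, would read as low as compound 1 or lower.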